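A few compounds are considered here, and "the series" means these few. Any claim that something is new, unique, unknown or untested is made for them only; others in the source may bear on it.

Measured compounds:
- Compound 1 `COc1ccc(C2=C(c3cc(OC)c(OC)c(OC)c3)C(=O)C(OC(C)=O)C2)cc1OC(C)C`, in an ADME assay on KB cells (Homo sapiens) for cytotoxicity, read by MTT assay, with a stated time of 72 h (a lower number here means a stronger inhibitor, a higher number a weaker inhibitor), gives only an assay limit, > 100 ug/mL.
- Compound 2 `CC(=O)OC1C/C(=N/O)C(c2ccccc2)=C1c1ccccc1` gives 9 ug/mL in this assay.
- Compound 3 `COc1ccc(C2=C(c3cc(OC)c(OC)c(OC)c3)C(=O)C(O)C2)cc1Cl` gives 2.5 ug/mL in this assay.

Among the two compounds with a true number, compound 2 holds the higher one, and the gap down to compound 3 lies beyond the usual scatter of this assay. Compound 1 stands apart from both, since its result is a limit rather than a number.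

Compound 4 `O/N=C1/CC(O)C(c2ccccc2)=C1c1ccccc1` is not yet measured. It differs from compound 2 in one place: hydrogen in place of acetyl on an oxygen on a saturated carbon. Read one bond further out, the acetoxy of compound 2 becomes a hydroxy in compound 4. Among the measured compounds shown here, no pair of measured compounds shows this exact change on its own, so the size of the step cannot be read from the numbers at hand; compound 3 carries a hydroxy on its saturated ring carbon and has the lower number, but it also differs in its aromatic rings, so its value says nothing direct about this step. The step from compound 2 to compound 4 is therefore expected to be modest, a 1.3-fold lower number from compound 2 to compound 4 (0.11 log units; within the scatter), and is estimated to stay within the scatter. Compound 4 is expected to give about 7 ug/mL, with a likely range from 2.5 ug/mL to 20 ug/mL.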

Compound 4, half-maximal inhibitory concentration: > 100 ug/mL
Compound 4 was reported as a limit; the forecaster's own chance of this, stated with the estimate: 5%; middle value at least 14-fold (1.15 log units) from the limit.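

On the oxygen on a saturated carbon, the acetyl group proves to matter in this assay: replacing it with hydrogen, which turns acetoxy into hydroxy, gives an at least 11-fold higher number from compound 2 to compound 4 (1.04 log units; beyond the scatter). Before this result, no pair of compounds isolated this position, so this is the first direct sign that the outcome on the core of compound 2 depends on what sits on this oxygen. The result for compound 4 is a limit and not a number, so the step gives only a minimum size, and its real size cannot be read: the limit of > 100 ug/mL in this assay, at which 2 of the 4 values shown sit.

Only acetyl and hydrogen appear on this oxygen in the compounds shown, so it stays open whether a longer chain such as butanoyl, a simple methyl ether or a carbamate would keep the value of compound 2 or lose it as hydrogen does. On these data alone, whether the same change from acetoxy to hydroxy behaves alike on the core of compound 3 also remains open.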